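This account rests on a few compounds, and the source may have more. Where it says the series, first, only, none or still open, it means among the compounds named here.

Measured so far in a functional assay on MDA-MB-231 cells (Homo sapiens) for antiproliferative activity, read by MTT assay, with a stated time of 72 h; a lower number here means a stronger inhibitor, a higher number a weaker inhibitor:
- compound 1 `CC(Nc1ncnc2ccc(-c3cnn(C4CCNCC4)c3)cc12)c1c(Cl)ccc(F)c1Cl`: 12600 nM
- compound 2 `CC(Oc1nc(N)nc2ccc(-c3cnn(C4CCNCC4)c3)cc12)c1c(Cl)ccc(F)c1Cl`: 7000 nM

For the measured compounds named here, compound 2 stands within the scatter of compound 1, the only other measured compound, so these two values do not separate the pair. Both values are weak on this read-out.

The next compound is compound 3 `CC(Oc1ncnc2ccc(-c3cnn(C4CCNCC4)c3)cc12)c1c(Cl)ccc(F)c1Cl`. Relative to compound 2, it has hydrogen in place of amino on an aromatic carbon, between two ring nitrogen atoms (hydrogen in place of amino on an aromatic carbon). Going by the values given here, no measured step isolates this change, since compound 1 and compound 2 differ in more than one place. The nearest guide is compound 1, which also has hydrogen on that carbon and gives 12600 nM. On that basis, no change beyond the scatter is expected in this assay, with any drift more likely towards a higher number, meaning a weaker inhibitor. The expected change is a 1.3-fold higher number from compound 2 to compound 3 (0.11 log units; within the scatter). For compound 3 the estimated value is 9000 nM, with an expected range of 4000 nM to 20000 nM.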

Compound 3, half-maximal inhibitory concentration: 6770 nM
Beside the measured number, compound 3's estimate is 1.3-fold (0.12 log units) above it, within the range that was stated.
By their numbers in this assay, from the lowest: compounds 3, 2 and 1 (each within the scatter of the next).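

In this assay, for the compounds shown here, the step with hydrogen in place of amino on the aromatic carbon between two ring nitrogen atoms is a 1.0-fold lower number from compound 2 to compound 3 (0.01 log units; within the scatter) and gives the first reading of this position on its own, free of any other difference in the structure. For this pair, the presence or absence of the amino group, with its one hydrogen-bond donor and one hydrogen-bond acceptor, does not separate the two compounds, so this single exchange on the shared core gives no handle on antiproliferative activity in these cells. No measurement on hand offers a reason for this result.

The compounds shown leave open whether a different group on this carbon, such as methyl, methoxy or dimethylamino, would separate from hydrogen and amino, since only these two substituents can be compared here. They also leave open whether amino at this position would read the same way in a compound that keeps the nitrogen linkage of compound 1 in place of the oxygen linkage of compound 2 and compound 3.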